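Amide aryl swap on a dopamine D4 agonist scaffold

The compounds below may be only part of what the source reports. "The series", "measured", "known", "first", "only" and "open" are said of these compounds alone.

Measured so far:
Compound 1 `Cc1cccc(NC(=O)CN2CCC(c3cccc(F)c3)CC2)c1`: 512 nM
Compound 2 `Cc1cc(C)cc(NC(=O)CN2CCC(c3cccc[n+]3[O-])CC2)c1`: 52 nM

In a functional assay on HEK293 cells for agonist activity at D(4) dopamine receptor (Homo sapiens), read by FLIPR (a lower number here means that less compound is needed, a higher number that more compound is needed for the effect), compound 2 gives the lower of the two numbers; compound 1 stands a wide gap away from it, and that gap lies beyond the usual scatter. Compound 3 `O=C(CN1CCC(c2cccc[n+]2[O-])CC1)Nc1ccccc1F` is not yet measured. It differs from compound 2 by 2-fluorophenyl in place of 3,5-dimethylphenyl on an amide-type nitrogen. For the measured compounds named here, no measured pair shows this change on its own, so its size is uncertain. The step from compound 2 to compound 3 is expected to raise the number, estimated at a 2.9-fold higher number from compound 2 to compound 3 (0.46 log units; beyond the scatter). Compound 3 is therefore expected to give about 150 nM, within a range of 50 nM to 500 nM.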

Compound 3, half-maximal effective concentration: 270 nM
Beside the measured number, compound 3's estimate is 1.8-fold (0.26 log units) below it, within the range that was stated.
By their numbers in this assay, from the lowest: compound 2; then compounds 3 and 1 (each within the scatter of the next).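

In this assay, the aryl group on the amide-type nitrogen matters: 2-fluorophenyl in place of 3,5-dimethylphenyl gives a 5.2-fold higher number from compound 2 to compound 3 (0.72 log units; beyond the scatter). This is the only change in a single place among the compounds shown, and so the first direct reading of this position. No available evidence accounts for the size or direction of this step.

On these data alone, the swap removes the two methyl groups and adds the fluorine at once, so their separate contributions remain open. An unsubstituted phenyl or a 3-methylphenyl on the same nitrogen, with the rest of compound 2 kept, could help separate them.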